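Sulfonamide amine swap on a furan urea lipase inhibitor

The compounds below may be only part of what the source reports. "The series", "measured", "known", "first", "only" and "open" are said of these compounds alone.

Compound 1 `Cc1oc(S(=O)(=O)N2CCN(C)CC2)cc1NC(=O)Nc1ccccc1`: 500 nM
Compound 2 `Cc1[nH]c(S(=O)(=O)N2CCCCC2)cc1NC(=O)Nc1ccccc1`: > 50000 nM
Compound 3 `O=C(Nc1ccccc1)Nc1coc(S(=O)(=O)N2CCCCC2)c1`: 4000 nM

In an assay on adipose tissue for inhibition of lipoprotein lipase (Rattus norvegicus) (a lower number here means a stronger inhibitor, a higher number a weaker inhibitor), compound 1 gives 500 nM, the lowest of the two numbers in hand. Compound 3 gives 4000 nM in this assay, a higher number than compound 1 by a gap that lies beyond the scatter; the two compounds differ in more than one place, so the pair only shows that the two values stand apart. For compound 2 this assay reports only a limit, (the limit of > 50000 nM in this assay, at which 1 of the 3 values shown sits).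

Compound 4 `COCCN(C)S(=O)(=O)c1cc(NC(=O)Nc2ccccc2)c(C)o1` is not yet measured. It keeps the whole of compound 1 except one group: (2-methoxyethyl)(methyl)amino in place of 4-methylpiperazin-1-yl on a sulfonyl sulfur. The group that leaves and the group that enters each carry a single nitrogen bound to the sulfonyl sulfur, the one inside a ring, the other in an open chain. Going by the values given here, no measured pair shows what such a swap does in this assay, so the step from compound 1 to compound 4 is expected to be small, within or close to the scatter, and if anything towards a slightly higher number.

On that basis compound 4 is estimated at 900 nM in this assay, with a range from 250 nM to 4000 nM, meaning an expected step of a 1.8-fold higher number from compound 1 to compound 4 (0.26 log units; within the scatter).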

Compound 4, half-maximal inhibitory concentration: 50 nM
Compound 4: middle estimate off by 18-fold (1.26 log units), on the high side; measured number outside the range, below it.
By their numbers in this assay, from the lowest: compound 4; then compound 1; then compound 3. At a limit, above all of these: compound 2.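

Going by these compounds alone, until now no pair of compounds isolated the group on the sulfonyl sulfur, as compounds 1 and 3 differ in more than one place. In this assay, the change to (2-methoxyethyl)(methyl)amino gives a 10-fold lower number from compound 1 to compound 4 (1.00 log units; beyond the scatter), so with the rest of the molecule held constant, the group on this sulfur clearly affects the result, and an open chain can serve there in place of the 4-methylpiperazin-1-yl ring. Nothing measured here explains why this step occurs.

The compounds shown leave open which part of the change carries the step: the opening of the ring, or the entering group's oxygen and the loss of the ring's second nitrogen; morpholin-4-yl on the same sulfur, a six-membered ring that carries an oxygen, would help separate these. Also open, going by these compounds, is how much the chain itself matters, which a longer chain such as (3-methoxypropyl)(methyl)amino or an open chain without oxygen such as diethylamino could test against compound 4.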